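The compounds below may be only part of what the source reports. "The series", "measured", "known", "first", "only" and "open" are said of these compounds alone.

Measured compounds, all in a functional assay on NT2 cells (Homo sapiens) for inhibition (a lower number here means a stronger inhibitor, a higher number a weaker inhibitor), as follows:
compound 1 `O=C(O)C[C@H](NC(=O)c1cncc(S(=O)(=O)NCc2ccccc2)c1)C(=O)CSCc1ccc(F)cc1` gives 59000 nM
compound 2 `O=C[C@H](CC(=O)O)NC(=O)c1cncc(S(=O)(=O)NC2CC2)c1` gives 57000 nM
compound 3 `CCN(CC)S(=O)(=O)c1cncc(C(=O)N[C@@H](CC(=O)O)C(=O)CSCc2ccc(F)cc2)c1` gives 12000 nM

Of these three, compound 3 has the lowest number, and compound 1 and compound 2 both sit higher by similar margins. The change now in view leads to compound 4 `CN(C)S(=O)(=O)c1cncc(C(=O)N[C@@H](CC(=O)O)C(=O)CSCc2ccc(F)cc2)c1` and reads dimethylamino in place of diethylamino on a sulfonyl sulfur in short, dimethylamino in place of diethylamino on a sulfonyl sulfur.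

Among the compounds with values here, only one measured step touches this place, namely a 4.9-fold lower number from compound 1 to compound 3 (0.69 log units; beyond the scatter) with diethylamino in place of benzylamino on a sulfonyl sulfur. That step is modest, and it shows that this assay responds to changes at this sulfur. It does not compare dimethylamino with diethylamino directly. Compound 2 differs from the others in more than one place, so it gives no clean comparison here.

A small shift is therefore expected, with a slightly higher number more likely than a lower one and nothing clearly beyond the scatter. The expected change is a 1.7-fold higher number from compound 3 to compound 4 (0.22 log units; within the scatter) on this estimate. For compound 4 the estimated value is 20000 nM with an expected range from 7000 nM to 55000 nM in this assay when it is measured.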

Compound 4, half-maximal inhibitory concentration: 21000 nM
Compound 4: the middle estimate sits 1.1-fold (0.02 log units) below what was measured, within the range that was stated.
By their numbers in this assay, from the lowest: compounds 3 and 4 (each within the scatter of the next); then compounds 2 and 1 (each within the scatter of the next).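

Working notes on the sulfonyl sulfur: in this assay, the exchange of diethylamino for dimethylamino gives a 1.8-fold higher number from compound 3 to compound 4 (0.24 log units; within the scatter), so this pair cannot be told apart and the size of the alkyl groups within this pair makes no readable difference. The second new comparison gives a 2.8-fold lower number from compound 1 to compound 4 (0.45 log units; beyond the scatter) and lies beyond the scatter, which shows that the advantage over benzylamino on this sulfur is not unique to diethylamino but is shared by dimethylamino. The data supplied offer no measurement that would explain either result.

From the compounds shown here alone, it remains open whether an unsubstituted amino group or a longer chain such as dipropylamino on the same sulfonyl sulfur would stay with compound 3 and compound 4 or move clearly away from them in this assay. Also open, going by these compounds, is whether any group at this sulfur can bring the series beyond these modest steps, and compound 2 cannot help to settle this, since it differs from the other compounds in more than one place.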